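Fluorobenzyl in Place of Trifluoropropyl on the Indazole Side Chain

The source may hold more compounds than are shown below. What is called first, only, known or untested is meant among the compounds shown, and "the series" means these compounds.

Compound 1 `CC1(C)C(=O)Nc2nc(-n3nc(CCCC(F)(F)F)c4cc(Cl)ccc43)nc(N)c21`: 117000 nM
Compound 2 `COC(=O)N(C)c1c(N)nc(-n2nc(Cc3c(F)ccc(F)c3F)c3cc(Cl)ccc32)nc1N`: 700 nM

In an assay on CHO cells for activation of soluble guanylate cyclase alpha1/beta1 complex (Homo sapiens), read by cGMP accumulation (on this read-out higher numbers stand for an effect only at larger amounts of compound and lower numbers for an effect already at smaller amounts), compound 1 gives 117000 nM, the highest of the two numbers shown; compound 2 gives 700 nM, a gap well beyond the scatter. Compound 3 `CC1(C)C(=O)Nc2nc(-n3nc(Cc4ccccc4F)c4cc(Cl)ccc43)nc(N)c21` keeps the core of compound 1 and changes only the side chain: 2-fluorophenyl in place of 3,3,3-trifluoropropyl on a saturated chain carbon bound to an aromatic carbon. Compound 2 also carries a fluorinated benzyl there, so a clear move toward lower numbers is expected from compound 1 to compound 3, a 39-fold lower number from compound 1 to compound 3 (1.59 log units; beyond the scatter). Compound 3 is estimated at 3000 nM, in a range from 500 nM to 20000 nM.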

Compound 3, half-maximal effective concentration: 18000 nM
For compound 3 the middle estimate is 6.0-fold (0.78 log units) below the measured one; the range from low to high includes it.
By their numbers in this assay, from the lowest: compound 2; then compound 3; then compound 1.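

On the core of compound 1, this assay responds to the side chain alone: 2-fluorophenyl in place of 3,3,3-trifluoropropyl on a saturated chain carbon bound to an aromatic carbon gives a 6.5-fold lower number from compound 1 to compound 3 (0.81 log units; beyond the scatter). Going by these compounds alone, this is the first change at this position that can be read in isolation, and an aromatic ring is tolerated there. No measurement available accounts for the step.

As far as these compounds go, it remains open whether the ring fluorine contributes to the step. From the compounds shown here alone, how an unsubstituted phenyl or a primary amine would read at this position also remains open.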